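This account rests on a few compounds, and the source may have more. Where it says the series, first, only, none or still open, it means among the compounds named here.

In a physicochemical assay for solubility, read by LC-MS, in phosphate buffer, with a stated time of 24 h, at pH 7.4 (a higher number here means a more soluble compound, a lower number a less soluble compound), compound 3 (`Cc1nc(CN(C)C)ccc1-c1cnc(NCc2c(F)ccc3c2CCO3)c2cn[nH]c(=O)c12`) stands at > 1000000 nM. That figure is a limit of the assay and not a number. Compound 1 (`Cc1nc(CO)ccc1-c1cnc(NCc2c(F)ccc3c2CCO3)c2cn[nH]c(=O)c12`) gives 3000 nM in this assay, and compound 2 (`CN(C)C(=O)c1cc(-c2cnc(NCc3c(F)ccc4c3CCO4)c3cn[nH]c(=O)c23)n(C)n1`) gives 3000 nM.

The next compound, compound 4 (`CN(c1ccn(C)n1)c1cnc(NCc2c(F)ccc3c2CCO3)c2cn[nH]c(=O)c12`), differs from compound 3 as follows: methyl(1-methyl-1H-pyrazol-3-yl)amino in place of 6-((dimethylamino)methyl)-2-methylpyridin-3-yl on an aromatic carbon. Methyl(1-methyl-1H-pyrazol-3-yl)amino thus sits in place of 6-((dimethylamino)methyl)-2-methylpyridin-3-yl on an aromatic carbon of the shared core.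

Within the data shown here, three measured steps bear on this change. Exchanging one substituent for another without a dimethylamino group gave no change at the digits printed from compound 1 to compound 2 (within the scatter). Dimethylamino in place of hydroxy gave an at least 330-fold higher number from compound 1 to compound 3 (2.52 log units; beyond the scatter), a large step ending on the limit. The pyridinyl group with dimethylamino in place of the pyrazolyl amide gave an at least 330-fold higher number from compound 2 to compound 3 (2.52 log units; beyond the scatter), which is equally large.

Compound 4 no longer carries the dimethylamino group, so it is expected to fall in with compound 1 at 3000 nM rather than with compound 3. The expected change is a large one towards a lower number, an at least 330-fold lower number from compound 3 to compound 4 (2.52 log units; beyond the scatter). For compound 4 the estimated value is 3000 nM, with an expected range from 500 nM to 20000 nM.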

Compound 4, solubility: 12000 nM
Compound 4: the middle estimate sits 4.0-fold (0.60 log units) below what was measured, and the stated range covers the measured number.
By their numbers in this assay, from the lowest: compounds 1 and 2 (each within the scatter of the next); then compound 4. At a limit, above all of these: compound 3.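

At this position of the shared core, the new group gives in this assay an at least 83-fold lower number from compound 3 to compound 4 (1.92 log units; beyond the scatter) and so does not keep the high end reached with 6-((dimethylamino)methyl)-2-methylpyridin-3-yl. The earlier compounds shown here without a dimethylamino group sat level with each other, whereas methyl(1-methyl-1H-pyrazol-3-yl)amino separates from both of them, with a 4.0-fold higher number from compound 2 to compound 4 (0.60 log units; beyond the scatter) and with a 4.0-fold higher number from compound 1 to compound 4 (0.60 log units; beyond the scatter) as modest steps beyond the scatter, so substituents lacking that group do not all share one number. The figure for compound 3 is a limit of the assay and not a number: the limit of > 1000000 nM in this assay, at which 1 of the 4 values shown sits.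

The compounds shown leave open whether the large step belongs to dimethylamino alone or would also appear with another amine, such as a morpholine or a primary amine, on the same saturated chain carbon. They also leave open whether a dimethylaminomethyl group carried on a pyrazole instead of the pyridine would give the same high end, and whether a carboxylic acid at that chain carbon would behave like the hydroxy of compound 1 or like the amine of compound 3.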